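A few compounds are considered here, and "the series" means these few. Any claim that something is new, unique, unknown or untested is made for them only; others in the source may bear on it.

Measured so far:
compound 1, `CCCN(CC1CC1)c1nc(C)nc2c(-c3ccc(OC)cc3C)c(C)nn12` — 1.96 nM
compound 2, `CCCN(CCC)c1nc(C)nc2c(-c3c(C)cc(OC)cc3OC)c(C)nn12` — 3.72 nM

In an assay on cell membranes for displacement of a labelled ligand from corticotropin-releasing factor receptor 1 (Rattus norvegicus) (a higher number here means a weaker inhibitor, a lower number a stronger inhibitor), compound 1 gives the lower of the two numbers, but compound 2 at 3.72 nM lies within the scatter of it, so the pair shows no order.

Compound 3, `COc1ccc(-c2c(C)nn3c(N4CCCC4)nc(C)nc23)c(C)c1`, is not yet measured. It differs from compound 1 in one place: pyrrolidin-1-yl in place of (cyclopropylmethyl)(propyl)amino on an aromatic carbon. Among the measured compounds shown here, no step of this kind exists among the measured compounds, so the direction rests on the change alone; a modest rise in the number, beyond the scatter, is expected.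

For compound 3 the estimate is 15 nM (range 4 nM to 60 nM), an expected step of a 7.7-fold higher number from compound 1 to compound 3 (0.88 log units; beyond the scatter).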

Compound 3, half-maximal inhibitory concentration: 80.7 nM
For compound 3 the middle estimate is 5.4-fold (0.73 log units) below the measured one; measured number outside the range, above it.
By their numbers in this assay, from the lowest: compounds 1 and 2 (each within the scatter of the next); then compound 3.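

In this assay, pyrrolidin-1-yl in place of (cyclopropylmethyl)(propyl)amino on this aromatic carbon, between two ring nitrogen atoms, gives a 41-fold higher number from compound 1 to compound 3 (1.61 log units; beyond the scatter). Among the compounds shown here, this is the first single-place step, and it shows that the number at this position depends strongly on which amino group sits there. No measurement available bears on the reason for the rise.

As far as these compounds go, whether the rise follows from closing the ring or from losing heavy atoms stays open. Diethylamino or piperidin-1-yl at this place would separate the two.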